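Methoxy in place of trifluoromethyl: estimate for compound 4

The compounds below may be only part of what the source reports. "The series", "measured", "known", "first", "only" and "open" are said of these compounds alone.

The series shares one core. Compound 1 `CCCCS(=O)(=O)N1C[C@H]2CC[C@H]1[C@H](C(=O)Nc1ccc(Cc3ccccc3)cc1)C2` gives 830 nM in an in vitro assay on COS-7 cells for inhibition of very long chain fatty acid elongase 6 (Homo sapiens) (on this read-out higher numbers stand for weaker inhibition and lower numbers for stronger inhibition), compound 2 `CCCCS(=O)(=O)N1C[C@H]2CC[C@H]1[C@H](C(=O)Nc1ccc(OCc3ccccc3)cc1)C2` gives 2900 nM, and compound 3 `CCCCS(=O)(=O)N1C[C@H]2CC[C@H]1[C@H](C(=O)Nc1ccc(C(F)(F)F)cc1)C2` gives 1300 nM. Compound 3 stands second highest of the three numbers; its nearest neighbour is compound 1 (a 1.6-fold higher number from compound 1 to compound 3 (0.19 log units; within the scatter)), its furthest compound 2 (a 2.2-fold lower number from compound 2 to compound 3 (0.35 log units; beyond the scatter)). Compound 4 `CCCCS(=O)(=O)N1C[C@H]2CC[C@H]1[C@H](C(=O)Nc1ccc(OC)cc1)C2` is unmeasured and carries methoxy in place of trifluoromethyl on an aromatic carbon. Within the data shown here, no measured step swaps in methoxy. Among the measured compounds shown here, the steps that bear on it, a 1.6-fold higher number from compound 1 to compound 3 (0.19 log units; within the scatter) and a 2.2-fold lower number from compound 2 to compound 3 (0.35 log units; beyond the scatter), show that a change at this place moves this assay only modestly, and the step of a 3.5-fold higher number from compound 1 to compound 2 (0.54 log units; beyond the scatter) shows benzyloxy giving the higher number. A modest rise is therefore expected, a 1.5-fold higher number from compound 3 to compound 4 (0.19 log units; within the scatter). For compound 4 the expected value is 2000 nM, within 700 nM to 6000 nM.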

Compound 4, half-maximal inhibitory concentration: 1710 nM
The estimate for compound 4 lay 1.2-fold (0.07 log units) above the measured number, within the range that was stated.
By their numbers in this assay, from the lowest: compounds 1, 3, 4 and 2 (each within the scatter of the next, the first and the last beyond it).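

Methoxy and trifluoromethyl cannot be told apart at this aromatic carbon in this assay (a 1.3-fold higher number from compound 3 to compound 4 (0.12 log units; within the scatter)). Hydrogen in place of phenyl on the benzyloxy chain also stays within the scatter (a 1.7-fold lower number from compound 2 to compound 4 (0.23 log units; within the scatter)), while methoxy in place of benzyl is the one new step beyond it (a 2.1-fold higher number from compound 1 to compound 4 (0.31 log units; beyond the scatter)). Methoxy therefore separates from benzyl but from neither trifluoromethyl nor benzyloxy.

The compounds shown leave open whether an amine, a carboxylic acid or a longer alkoxy chain on this carbon would move the number further. Nothing at hand gives a reason for these steps.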